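Changing the Group on the Carbonyl, Without a Measured Guide

The compounds below may be only part of what the source reports. "The series", "measured", "known", "first", "only" and "open" are said of these compounds alone.

Of the compounds shown here, three have been measured in a functional assay on CHO cells with adenosine receptor A1 (Homo sapiens) as the target, read by cAMP accumulation and immunoassay, with a stated time of 6 min, tested at 1 uM; a lower number here means a stronger effect, a higher number a weaker effect of the compound at the concentration tested. Compound 1 `Nc1scc(CN2CCN(c3ccc(Cl)cc3F)CC2)c1C(=O)c1ccc(Cl)cc1` gives -57%. Compound 2 `Nc1scc(CN2CCN(c3ccncc3)CC2)c1C(=O)c1ccc(Cl)cc1` gives -8.3%. Compound 3 `Nc1scc(CN2CCN(c3c(F)cccc3F)CC2)c1C(=O)c1cccc(C(F)(F)F)c1` gives 1.3%. On the numbers shown, compound 3 has the highest value, but its distance from compound 2 is within the scatter; only its distance from compound 1 is beyond it.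

One measured step changes a single place: a number 48.7 percentage points higher from compound 1 to compound 2 (beyond the scatter). That change sits on an amine nitrogen in a ring, far from the carbonyl.

Compound 4 `Nc1scc(CN2CCN(c3c(F)cccc3F)CC2)c1C(=O)c1ccc(Cl)cc1` has not yet been measured. It differs from compound 3 in one place: 4-chlorophenyl in place of 3-(trifluoromethyl)phenyl on a carbonyl carbon. Going by the values given here, no measured step touches the group on the carbonyl carbon. Compound 1 and compound 2 carry 4-chlorophenyl there while compound 3 carries 3-(trifluoromethyl)phenyl, but each of these pairs also differs on the amine nitrogen in a ring, so their values cannot be read as the effect of the carbonyl group alone. Among the compounds with values here, the single measured step therefore does not bear on this change. With no direct guide, the expected step is a number 6.3 percentage points lower from compound 3 to compound 4 (within the scatter), that is, none beyond the scatter. For compound 4 in this assay the estimate is -5%, with an expected range from -35% to 15%.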

Compound 4, a percentage reported as activity, at one concentration (the size of the read-out at that concentration, not a potency): -65%
Compound 4: the middle estimate sits 60 percentage points above what was measured; measured number outside the range, below it.
By their numbers in this assay, from the lowest: compounds 4 and 1 (each within the scatter of the next); then compounds 2 and 3 (each within the scatter of the next).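

In this assay, the group on the carbonyl carbon now has a measured step of its own: a number 66.3 percentage points lower from compound 3 to compound 4 (beyond the scatter), for 4-chlorophenyl in place of 3-(trifluoromethyl)phenyl, with 2,6-difluorophenyl kept on the amine nitrogen, which shows that this place is far from silent. With 4-chlorophenyl held on the carbonyl carbon, the group on the amine nitrogen can also be compared again: there is a number 56.7 percentage points lower from compound 2 to compound 4 (beyond the scatter) for 2,6-difluorophenyl in place of pyridin-4-yl, but only a number 8 percentage points lower from compound 1 to compound 4 (within the scatter) for 2,6-difluorophenyl in place of 4-chloro-2-fluorophenyl, so these last two groups cannot be told apart here. Nothing shown gives a measured reason for the size of any of these steps.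

This single swap changes both the atoms on the ring and the place they occupy in the group's name, and the compounds shown do not separate the two changes. Also open, as far as these compounds go, is how a plain phenyl, a 3-chlorophenyl or a 4-methoxyphenyl on the carbonyl carbon would compare, and whether the step holds with another group on the amine nitrogen.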